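Methoxy for (dimethylamino)methyl on a quinazoline urea

The source may report more compounds than this note shows. Statements on the series, on what has been measured and on what is new or still open speak of the compounds shown alone.

Compound 1 `CN(C)Cc1ccc(NC(=O)Nc2ccc3ncnc(Nc4cccc(C(F)(F)F)c4)c3c2)cc1`: 1120 nM
Compound 2 `C#Cc1cccc(Nc2ncnc3ccc(NC(=O)Nc4ccc(CN(CC)CC)cc4)cc23)c1`: 2250 nM

Both were measured in a functional assay on A549 cells (Homo sapiens) for antiproliferative activity, read by MTT assay, with a stated time of 72 h; a lower number here means a stronger inhibitor, a higher number a weaker inhibitor. Compound 1 has the lowest of the two numbers; compound 2 sits a short way from it, and the two are within the usual scatter, so no order between them is claimed. Compound 3 `COc1ccc(NC(=O)Nc2ccc3ncnc(Nc4cccc(C(F)(F)F)c4)c3c2)cc1` has not been measured. It differs from compound 1 by methoxy in place of (dimethylamino)methyl on an aromatic carbon. Among the compounds with values here, no measured pair shows this change, so its size is open; a modest step, if any, is expected. Compound 3 is estimated at 1500 nM (range 500 nM to 4500 nM), which is expected to be a step of a 1.3-fold higher number from compound 1 to compound 3 (0.13 log units; within the scatter).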

Compound 3, half-maximal inhibitory concentration: 9470 nM
Compound 3: the middle estimate sits 6.3-fold (0.80 log units) below what was measured, and the stated range ends below it.
By their numbers in this assay, from the lowest: compounds 1 and 2 (each within the scatter of the next); then compound 3.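

In this assay, the step from (dimethylamino)methyl to methoxy on this aromatic carbon, para to a large group, gives an 8.5-fold higher number from compound 1 to compound 3 (0.93 log units; beyond the scatter) and lies beyond the scatter. Within the data shown here, this is the first sign that the group at this place matters, which compounds 1 and 2, differing in more than one place, could not show. Nothing available gives a reason for the step. Still open, from the compounds shown here alone, is whether losing the amine or gaining the methoxy drives it. A methyl at this place would separate the two, and a piperidinylmethyl group would test other amines.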